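Swapping a fluorophenyl for cyclohexenyl on the alkyne

The compounds below may be only part of what the source reports. "The series", "measured", "known", "first", "only" and "open" are said of these compounds alone.

Compound 2 `NC(=O)c1nc(C#Cc2cccc(F)c2)n(COCCO)n1` carries a 3-fluorophenyl on a triple-bonded carbon. In an ADME assay on Huh-5-2 cells (Homo sapiens) for cytotoxicity (a lower number here means that less compound is tolerated, a higher number that more compound is tolerated), compound 2 gives 29 ug/mL. Its neighbour compound 1 `NC(=O)c1nc(C#Cc2ccc(F)cc2)n(COCCO)n1` carries a 4-fluorophenyl at the same place. In this assay compound 1 reaches only a limit, > 50 ug/mL. Among the compounds with values here, the single measured step, an at least 1.7-fold lower number from compound 1 to compound 2 (0.23 log units; that floor lies within the scatter), is the only guide available, and it rests on (the limit of > 50 ug/mL in this assay, at which 1 of the 2 values shown sits). Among the two values shown, compound 2 holds the only number; the other value is a limit.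

Compound 3 `NC(=O)c1nc(C#CC2=CCCCC2)n(COCCO)n1` differs from compound 2 by cyclohex-1-en-1-yl in place of 3-fluorophenyl on a triple-bonded carbon. Within the data shown here, no measured step exchanges an aromatic ring for a non-aromatic one, so the step from compound 1 to compound 2 bears on it only loosely: it shows that a change at this position moved the number by no more than its own size, which lies within the scatter. The step from compound 2 to compound 3 is therefore expected to be small in this assay, a 1.0-fold higher number from compound 2 to compound 3 (0.01 log units; within the scatter), with no direction claimed beyond the scatter. For compound 3 the estimated value in this assay is 30 ug/mL, with a range from 12 ug/mL to 50 ug/mL.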

Compound 3, half-maximal cytotoxic concentration: > 50 ug/mL
Compound 3 was reported as a limit (the forecaster's own chance of this, stated with the estimate: 30%); middle value at least 1.6-fold (0.22 log units) from the limit.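

In this assay, within the data shown here, the place on the triple-bonded carbon now holds a non-aromatic ring with no fluorine, where the earlier compounds both held a fluorophenyl, and the change gives an at least 1.7-fold higher number from compound 2 to compound 3 (0.23 log units; that floor lies within the scatter). That floor alone therefore establishes no real difference between cyclohex-1-en-1-yl and 3-fluorophenyl, though it does show that an aromatic ring at this place is not required for a compound to reach the limit, as compound 3 does. The step between compound 1 and compound 3 cannot be read, and the 4-fluorophenyl and cyclohex-1-en-1-yl groups cannot be ordered, because both compounds stop at the same limit: the limit of > 50 ug/mL in this assay, at which 2 of the 3 values shown sit.

As far as these compounds go, how far compound 1 and compound 3 actually lie beyond that limit remains open, and so does whether either of them truly differs from compound 2 by more than the usual scatter. Also open, from the compounds shown here alone, is how this assay would respond to a fully saturated cyclohexyl ring, a small cyclopropyl ring or a short chain ending in an amine on the triple-bonded carbon.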